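Tolerability notes across compounds 1 to 4

A few compounds are considered here, and "the series" means these few. Any claim that something is new, unique, unknown or untested is made for them only; others in the source may bear on it.

The series is followed in an ADME assay on HepG2 2.2.15 cells (Homo sapiens) for cytotoxicity; a higher number here means that more compound is tolerated, a lower number that less compound is tolerated. Compound 1 `CC(C)(C)OC(=O)Nc1ncc(C(Oc2ccc(F)c(Cl)c2)c2ccc(Cl)cc2)s1` reaches only the limit of this assay, reported as > 50000 nM. Compound 2 `O=C(Nc1ncc(C(OCc2ccc(F)cc2F)c2ccccc2)s1)c1cccs1` is entered in this assay as "not toxic" (no number reported), without a number. Compound 3 `CCN(CC)C(=O)Nc1ncc(C(Oc2ccc3cc(Br)ccc3c2)c2ccc(Cl)cc2)s1` is likewise entered in this assay as "not toxic" (no number reported), again without a number. Thus no single number is available for compound 3; of the three entries, one sits at the limit of > 50000 nM in this assay, at which 1 of the 3 values shown sits, and the other two carry only a verbal statement of no toxicity. Compound 4 `Cc1noc(C)c1C(=O)Nc1ncc(C(Oc2ccc3cc(Br)ccc3c2)c2ccc(Cl)cc2)s1` differs from compound 3 by 3,5-dimethyl-1,2-oxazol-4-yl in place of diethylamino on a carbonyl carbon. Among the compounds with values here, no measured step exists in this assay, so the size of the change from compound 3 to compound 4 cannot be read from the data. All three entries in this assay show no toxicity within the tested range, and no shift beyond the usual scatter is expected in either direction. Compound 4 is therefore expected to be tolerated in this assay at an estimated 80000 nM, with a range of 30000 nM to 200000 nM, most likely reported again only as a limit.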

Compound 4, half-maximal cytotoxic concentration: "not toxic" (no number reported)
For compound 4 the study gives words and no number, so the estimate cannot be set against anything.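

In this assay, within the data shown here, compound 3 and compound 4 are both entered only as "not toxic", so no step between them can be read. The compounds shown leave open whether 3,5-dimethyl-1,2-oxazol-4-yl in place of diethylamino shifts tolerance at all, with one numerical entry standing as a limit: the limit of > 50000 nM in this assay, at which 1 of the 4 values shown sits.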